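Adding a tert-butoxy group to a distal phenyl chain

The source may hold more compounds than are shown below. What is called first, only, known or untested is meant among the compounds shown, and "the series" means these compounds.

Measured so far:
- compound 1, `CN[C@@H](CC(C)C)CN(C(=O)[C@@H]1C[C@H]1c1ccccc1)c1ccc(-c2ccccc2)cc1`: 2 nM in a functional assay for agonist activity at G protein-coupled receptor 88 (Homo sapiens), read by HTRF and cAMP accumulation; a lower number here means that less compound is needed, a higher number that more compound is needed for the effect
- compound 2, `CC(C)C[C@H](N)CN(C(=O)[C@@H]1C[C@H]1c1ccccc1)c1ccc(-c2ccccc2F)cc1`: in this assay compound 2 gives 1600 nM
- compound 3, `CCc1ccc(-c2ccc(N(C[C@@H](N)[C@@H](C)CC)C(=O)[C@@H]3C[C@H]3c3ccccc3)cc2)cc1`: in this assay compound 3 gives 44 nM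

Compound 3 stands second highest of the three numbers. Compound 1 shows a lower number and compound 2 a higher one, and both gaps lie beyond the usual scatter; since each pair differs in several places, nothing more can be drawn from them.

The unmeasured compound 4, `CC[C@H](C)[C@H](N)CN(C(=O)[C@@H]1C[C@H]1c1ccccc1)c1ccc(-c2ccc(COC(C)(C)C)cc2)cc1`, differs from compound 3 in one place: tert-butoxy in place of methyl on a saturated chain carbon bound to an aromatic carbon. With no single-change comparison available, the expected change in this assay is a modest rise in the number, a step at most a little beyond the scatter. Compound 4 is estimated at 120 nM, within 30 nM to 600 nM, an expected step of a 2.7-fold higher number from compound 3 to compound 4 (0.44 log units; beyond the scatter).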

Compound 4, half-maximal effective concentration: 280 nM
Estimate against measurement, compound 4: 2.3-fold (0.37 log units) below, within the range that was stated.
By their numbers in this assay, from the lowest: compound 1; then compound 3; then compound 4; then compound 2.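

In this assay, putting tert-butoxy in place of methyl on a saturated chain carbon bound to an aromatic carbon gives a 6.4-fold higher number from compound 3 to compound 4 (0.80 log units; beyond the scatter) in this pair. Within the data shown here, this is the first comparison here that differs in one place only, and it shows that this position responds to the change, with more compound needed for the effect. Nothing shown gives a reason for the step. Still open, as far as these compounds go, is how a shorter ether such as methoxy, an amine or a carboxylic acid would read in the same place.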